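The source may report more compounds than this note shows. Statements on the series, on what has been measured and on what is new or still open speak of the compounds shown alone.

Measured in a functional assay on A2780 cells (Homo sapiens) for inhibition, with a stated time of 72 h; on this read-out higher numbers stand for weaker inhibition and lower numbers for stronger inhibition:
Compound 1 `CC(=O)O[C@@]1([C@@H]2/C(C)=C(/O)C(=O)C3=C(C)[C@@H](OC(=O)[C@H](O)[C@H](C=C(C)C)NC(=O)OC(C)(C)C)C[C@@](O)([C@H]2OC(=O)c2cccc(Cl)c2)C3(C)C)CO[C@@H]1CCO`: 1.7 nM
Compound 2 `CC(=O)O[C@@]1([C@@H]2/C(C)=C(/O)C(=O)C3=C(C)[C@@H](OC(=O)[C@H](O)[C@H](CC(C)C)NC(=O)OC(C)(C)C)C[C@@](O)([C@H]2OC(=O)c2cccc(F)c2)C3(C)C)CO[C@@H]1CCO`: 12.8 nM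

Compound 2 stands at 12.8 nM, the higher of the two numbers and so the weaker inhibition, with a gap to compound 1 that lies beyond the usual scatter. Compound 3 `CC(=O)O[C@@]1([C@@H]2/C(C)=C(/O)C(=O)C3=C(C)[C@@H](OC(=O)[C@H](O)[C@H](CC(C)C)NC(=O)OC(C)(C)C)C[C@@](O)([C@H]2OC(=O)c2cccc(Cl)c2)C3(C)C)CO[C@@H]1CCO` is compound 2 with a single change: chloro in place of fluoro on an aromatic carbon. Within the data shown here, no measured pair isolates this swap. Compound 1 also carries the chloro but differs from compound 2 in a second place as well, so the number of compound 1 at 1.7 nM hints at a direction without fixing a size. A moderate move toward stronger inhibition is therefore expected in this assay, with an estimated 2.6-fold lower number from compound 2 to compound 3 (0.41 log units; beyond the scatter). For compound 3 the expected value is 5 nM, with an estimated range of 1.8 nM to 13 nM.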

Compound 3, half-maximal inhibitory concentration: 4.6 nM
Estimate against measurement, compound 3: 1.1-fold (0.04 log units) above; low and high end bracket the measured number.
By their numbers in this assay, from the lowest: compound 1; then compound 3; then compound 2.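

In this assay, with the isobutyl chain held constant, chloro in place of fluoro on the aromatic ring gives a 2.8-fold lower number from compound 2 to compound 3 (0.44 log units; beyond the scatter), so this swap now has a measured size of its own, modest but beyond the scatter. Compound 3 also separates the two differences between compound 1 and compound 2: with chloro held constant, isobutyl in place of 2-methylprop-1-en-1-yl gives a 2.7-fold higher number from compound 1 to compound 3 (0.43 log units; beyond the scatter), which shows that the chain also counts on its own. Nothing measured here bears on why either step occurs.

Only fluoro and chloro are shown on that aromatic carbon, so the effect of bromo, methoxy or a nitrile there remains open. Also open is whether the halogen swap would have the same size on a compound carrying the 2-methylprop-1-en-1-yl chain, as only the chloro form is shown with it.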